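The source may hold more compounds than are shown below. What is called first, only, known or untested is meant among the compounds shown, and "the series" means these compounds.

Two close relatives of the same shared core have been measured in an assay on isolated protein for inhibition of kallikrein-7 (Mus musculus), read by fluorescence, with stated times of 10 min and 30 min; a lower number here means a stronger inhibitor, a higher number a weaker inhibitor. Compound 1, `CC1=NC(c2cn(S(=O)(=O)c3ccccc3)c3ccc(C)cc23)CN1`, carries a plain phenyl on its sulfonyl sulfur, and in this assay compound 1 gives 15000 nM. Compound 2, `CC1=NC(c2cn(S(=O)(=O)c3cccc(Cl)c3)c3ccc(C)cc23)CN1`, differs only by chloro in place of hydrogen on an aromatic carbon, and in this assay compound 2 gives 10000 nM. The step of a 1.5-fold lower number from compound 1 to compound 2 (0.18 log units; within the scatter) is the only one on record, and it is within the scatter, so compound 1 and compound 2 cannot be told apart on these numbers.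

Compound 3, `CC1=NC(c2cn(S(=O)(=O)c3ccccc3F)c3ccc(C)cc23)CN1`, has not yet been measured. It differs from compound 2 by 2-fluorophenyl in place of 3-chlorophenyl on a sulfonyl sulfur. Going by the values given here, the one measured step bears on it only loosely: it shows that moving from an unsubstituted phenyl to a chlorinated one changed nothing beyond the scatter, and nothing on record speaks to a fluorine on this ring. The expected step from compound 2 to compound 3 in this assay is therefore small, a 1.3-fold higher number from compound 2 to compound 3 (0.11 log units; within the scatter), with no direction beyond the scatter. Compound 3 is estimated at 13000 nM, within 5000 nM to 35000 nM.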

Compound 3, half-maximal inhibitory concentration: 6400 nM
Compound 3: middle estimate off by 2.0-fold (0.31 log units), on the high side; low and high end bracket the measured number.
By their numbers in this assay, from the lowest: compounds 3, 2 and 1 (each within the scatter of the next, the first and the last beyond it).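

In this assay, the ring on the sulfonyl sulfur now shows its first change beyond the scatter: a fluorine added to the plain phenyl gives a 2.3-fold lower number from compound 1 to compound 3 (0.37 log units; beyond the scatter), a modest step. Exchanging one halogen-bearing ring for the other gives a 1.6-fold lower number from compound 2 to compound 3 (0.19 log units; within the scatter), which is within the scatter, so 2-fluorophenyl and 3-chlorophenyl cannot be told apart here, even though only the fluorinated ring clears the scatter against the plain phenyl. No measurement on record explains why the plain phenyl can be told apart from one of these rings but not the other.

Compound 2 and compound 3 differ in both the halogen and its place on the ring, so these compounds cannot separate the effect of changing the atom from the effect of moving it. Also open, on these data alone, is how the numbers would respond to a different kind of group on this ring, such as a methoxy group or an amine, and whether any such change would give a step larger than this modest one.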